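Methyl on the ring nitrogen of compound 2

The source may report more compounds than this note shows. Statements on the series, on what has been measured and on what is new or still open speak of the compounds shown alone.

Three compounds of this series carry numbers in a functional assay on HCT-15 cells (Homo sapiens) for inhibition; on this read-out lower numbers stand for stronger inhibition and higher numbers for weaker inhibition. Compound 1 `COc1ccc(-c2cncn2-c2cc(OC)c(OC)c(OC)c2)cc1O` gives 89 nM. Compound 3 `COc1ccc(-c2ocnc2-c2cc(OC)c(OC)c(OC)c2)cc1N` gives 11 nM in this assay. Compound 2 `COc1cc(-n2cncc2-c2ccc3[nH]ccc3c2)cc(OC)c1OC` gives 350 nM in this assay, the highest of the three numbers: compound 1 stands nearest with a lower number, compound 3 furthest with a lower number, both gaps beyond the scatter, so compound 2 is the weakest inhibitor among the three.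

Compound 4 `COc1cc(-n2cncc2-c2ccc3c(ccn3C)c2)cc(OC)c1OC` differs from compound 2 in one place: methyl in place of hydrogen on an aromatic nitrogen. Within the data shown here, no measured pair shares this change, so no step can be drawn from measured numbers. The change is a single heavy atom with no ring and no acceptor entering, so only a small step is expected for compound 4, in either direction or none beyond the scatter, and the step from compound 2 is estimated at a 1.3-fold higher number from compound 2 to compound 4 (0.11 log units; within the scatter). Compound 4 is therefore expected to give about 450 nM in this assay, within a range from 150 nM to 1400 nM.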

Compound 4, half-maximal inhibitory concentration: 14 nM
Compound 4: the middle estimate sits 32-fold (1.51 log units) above what was measured; measured number below the stated range.
By their numbers in this assay, from the lowest: compounds 3 and 4 (each within the scatter of the next); then compound 1; then compound 2.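

In this assay the aromatic nitrogen of the five-membered ring, part of the fused system, turns out to be a sensitive position: methyl in place of hydrogen there gives a large step toward stronger inhibition (a 25-fold lower number from compound 2 to compound 4 (1.40 log units; beyond the scatter)). The earlier compounds shown here could not show this, as no two of them differ in one place, and here a change of a single heavy atom, with no ring entering, moves the number well beyond the scatter. Nothing at hand bears on what lies behind a step of this size.

Still open, as far as these compounds go, is whether the gain is particular to methyl or extends to other groups on this nitrogen, such as ethyl, a longer chain or acetyl. Also open, from the compounds shown here alone, is whether the same change gives a comparable step on a core other than that of compound 2.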